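Swapping a pyridinylmethyl ether for a cyclohexylmethyl ether

The source may hold more compounds than are shown below. What is called first, only, known or untested is meant among the compounds shown, and "the series" means these compounds.

The compounds here share one acid-bearing core and differ only in the group hung from an oxygen on the aromatic ring. Compound 1 `CCCC/C(=C\c1cc(Oc2ccccc2)ccc1OCc1ccc(C(F)(F)F)cc1)C(=O)O` gives 2100 nM in an assay on isolated protein for inhibition of Polyunsaturated fatty acid 5-lipoxygenase (Homo sapiens), read by HPLC, with a stated time of 15 min; a lower number here means a stronger inhibitor, a higher number a weaker inhibitor. Compound 2 `CCCC/C(=C\c1cc(OCc2ccc(OCc3ccccc3)cc2)ccc1OCc1ccc(C(F)(F)F)cc1)C(=O)O` is reported as "not active" (no number reported) in this assay. Compound 3 `CCCC/C(=C\c1cc(OCc2cccnc2)ccc1OCc1ccc(C(F)(F)F)cc1)C(=O)O` gives 2300 nM in this assay. Compound 3 and compound 1 lie within the scatter of each other, so neither can be ranked above the other; the step of a 1.1-fold higher number from compound 1 to compound 3 (0.04 log units; within the scatter) shows how little that exchange mattered.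

Compound 4 `CCCC/C(=C\c1cc(OCC2CCC(C(F)(F)F)CC2)ccc1OCc1ccc(C(F)(F)F)cc1)C(=O)O` has not yet been measured. The change from compound 3 is 4-(trifluoromethyl)cyclohexyl in place of pyridin-3-yl on a saturated chain carbon bound to an oxygen on an aromatic ring.

Going by the values given here, only one measured step touches this position, and it was flat: a 1.1-fold higher number from compound 1 to compound 3 (0.04 log units; within the scatter). The entry for compound 2, which carries a much larger group at the same oxygen, shows that this position does not accept everything. The group entering in compound 4 is larger than the one it replaces but smaller than that of compound 2, so a modest loss is the expected outcome, with a 2.2-fold higher number from compound 3 to compound 4 (0.34 log units; beyond the scatter) as the estimated step. The estimate for compound 4 in this assay is therefore 5000 nM, expected to fall between 1500 nM and 20000 nM.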

Compound 4, half-maximal inhibitory concentration: 1700 nM
For compound 4 the middle estimate is 2.9-fold (0.47 log units) above the measured one; the measured number falls inside the stated range.
By their numbers in this assay, from the lowest: compounds 4, 1 and 3 (each within the scatter of the next).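

In this assay the change gives a 1.4-fold lower number from compound 3 to compound 4 (0.13 log units; within the scatter), and the comparison with the phenyl group of compound 1 gives a 1.2-fold lower number from compound 1 to compound 4 (0.09 log units; within the scatter). Going by these compounds alone, the earlier step showed only that a phenyl group and a (pyridin-3-yl)methyl group could be exchanged at this oxygen, whereas this result extends that to a group with a non-aromatic ring of carbon only, no hydrogen-bond acceptor and a trifluoromethyl substituent, so neither an aromatic ring nor a ring nitrogen is needed to stay in this range among compounds 1, 3 and 4. Compound 2 goes against any claim that this position takes every group, and steps to it cannot be read, as it has no number, so the size at which activity disappears remains unplaced.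

The compounds shown leave open whether a hydrogen-bond donor such as an amine or a charged group such as a carboxylic acid on this ring would be accepted at this oxygen, or whether a longer chain would be. Nothing available here bears on why such different groups give numbers within the scatter of one another.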